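A few compounds are considered here, and "the series" means these few. Any claim that something is new, unique, unknown or untested is made for them only; others in the source may bear on it.

Compound 1 `O=C(CCc1cccc2c1B(O)OC2)Nc1cccc(Br)c1`, compound 2 `O=C(CCc1cccc2c1B(O)OC2)Nc1cccc(I)c1` and compound 3 `CC(C)c1cccc(NC(=O)CCc2cccc3c2B(O)OC3)c1` share one core and differ only in a single group on an aromatic carbon. In a functional assay on HCT-116 cells (Homo sapiens) for antiproliferative activity, read by MTT assay, with a stated time of 72 h (a higher number here means a weaker inhibitor, a lower number a stronger inhibitor), compound 1 gives 1400 nM, compound 2 gives 2300 nM, and compound 3 gives 1600 nM. Compound 3 stands close to both of the others: there is a 1.1-fold higher number from compound 1 to compound 3 (0.06 log units; within the scatter), and a 1.4-fold lower number from compound 2 to compound 3 (0.16 log units; within the scatter), so the three numbers cannot be told apart with confidence. Compound 4 `C#Cc1cccc(NC(=O)CCc2cccc3c2B(O)OC3)c1` has not yet been measured. It differs from compound 3 in one place: ethynyl in place of isopropyl on an aromatic carbon. Within the data shown here, the steps that bear on this change are the ones in which the group at that same position was exchanged. Putting isopropyl in place of bromo or iodo moved the number only within the scatter, and the exchange of the two halogens, a 1.6-fold higher number from compound 1 to compound 2 (0.22 log units; within the scatter), was likewise small. Three different groups at that position have therefore given much the same result, which suggests that ethynyl will do so too, although nothing in this set shows how a group with a triple bond behaves there. For compound 4 the expected step in this assay is a 1.1-fold higher number from compound 3 to compound 4 (0.03 log units; within the scatter), that is, no movement beyond the scatter. The estimate for compound 4 is 1700 nM, within a range from 800 nM to 3600 nM.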

Compound 4, half-maximal inhibitory concentration: 3600 nM
For compound 4 the middle estimate is 2.1-fold (0.33 log units) below the measured one, and the stated range covers the measured number.
By their numbers in this assay, from the lowest: compounds 1, 3, 2 and 4 (each within the scatter of the next, the first and the last beyond it).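

In this assay, among these compounds, ethynyl is the first group at this position to move the number beyond the scatter, with a 2.3-fold higher number from compound 3 to compound 4 (0.35 log units; beyond the scatter) when it replaces isopropyl and a 2.6-fold higher number from compound 1 to compound 4 (0.41 log units; beyond the scatter) when it replaces bromo, both modest steps towards a weaker inhibitor. The position is therefore not wholly indifferent to the group it carries, although ethynyl cannot be told apart from iodo, as a 1.6-fold higher number from compound 2 to compound 4 (0.19 log units; within the scatter) shows, so the effect remains small and does not set ethynyl apart from all the earlier groups. No measurement here accounts for the difference between ethynyl and the groups it replaces.

The groups shown at this position contain only carbon or a halogen, which leaves open how an amine, a carboxylic acid or a nitrile would behave there. As far as these compounds go, it also remains open whether a longer chain ending in a triple bond would give a number like that of compound 4, and whether ethynyl would have a similar effect elsewhere on the same aromatic ring.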